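Changing the Aryl Group on the Carbonyl: Compound 3

The source may hold more compounds than are shown below. What is called first, only, known or untested is meant among the compounds shown, and "the series" means these compounds.

Compound 1 `COc1ccc(-c2cc3ccccc3nc2/C=C/C(=O)c2ccc(O)cc2)cc1`: 6930 nM
Compound 2 `COc1ccc(-c2cc3ccccc3nc2/C=C/C(=O)c2ccc(OC)c(OC)c2)cc1`: 7540 nM

In a functional assay on NCI-H460 cells (Homo sapiens) for antiproliferative activity, read by XTT assay, with a stated time of 72 h (a lower number here means a stronger inhibitor, a higher number a weaker inhibitor), compound 1 gives 6930 nM and compound 2 gives 7540 nM. The step of a 1.1-fold higher number from compound 1 to compound 2 (0.04 log units; within the scatter) lies within the scatter, so compounds 1 and 2 cannot be told apart on these numbers. Compound 3 `COc1ccc(-c2cc3ccccc3nc2/C=C/C(=O)c2ccco2)cc1` carries the change (furan-2-yl in place of 3,4-dimethoxyphenyl on a carbonyl carbon). Within the data shown here, the only measured step at this position, a 1.1-fold higher number from compound 1 to compound 2 (0.04 log units; within the scatter), left the number unchanged, which points to no step beyond the scatter in this assay for this change either. Compound 3 is therefore expected to give 8000 nM, between 3000 nM and 25000 nM, a step of a 1.1-fold higher number from compound 2 to compound 3 (0.03 log units; within the scatter).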

Compound 3, half-maximal inhibitory concentration: 6430 nM
For compound 3 the middle estimate is 1.2-fold (0.09 log units) above the measured one; the measured number falls inside the stated range.
By their numbers in this assay, from the lowest: compounds 3, 1 and 2 (each within the scatter of the next).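

At this position, the change from the substituted phenyl groups to the smaller five-membered aromatic ring of furan-2-yl still gives no step beyond the scatter in this assay (a 1.2-fold lower number from compound 2 to compound 3 (0.07 log units; within the scatter)). The same holds against the 4-hydroxyphenyl group (a 1.1-fold lower number from compound 1 to compound 3 (0.03 log units; within the scatter)), so the three aryl groups on the carbonyl carbon cannot be told apart here. No evidence is available that bears on this result. The compounds shown leave open how an amine or a simple alkyl chain on that carbonyl carbon would compare, and so whether an aromatic ring matters there at all.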